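Pyridyl to pyrimidinyl swap on a biaryl amide

A few compounds are considered here, and "the series" means these few. Any claim that something is new, unique, unknown or untested is made for them only; others in the source may bear on it.

Compound 1 `CC(C)(C)c1ccc(NC(=O)c2ccc(-c3ccccn3)cc2)cc1`: 31 nM
Compound 2 `CC(C)(C)c1ccc(NC(=O)c2ccc(-c3ccncc3)cc2)cc1`: 280 nM

In a functional assay on Dorsal root ganglion for antagonist activity at transient receptor potential cation channel subfamily V member 1 (Rattus norvegicus) (on this read-out higher numbers stand for weaker inhibition and lower numbers for stronger inhibition), compound 2 stands highest of the two measured compounds, the step of a 9.0-fold higher number from compound 1 to compound 2 (0.96 log units; beyond the scatter) setting it apart from compound 1. Compound 3 `CC(C)(C)c1ccc(NC(=O)c2ccc(-c3ncccn3)cc2)cc1` is not yet measured; it differs from compound 2 by pyrimidin-2-yl in place of pyridin-4-yl on an aromatic carbon. Among the measured compounds shown here, no measured step covers this exact change; the only step, from compound 1 to compound 2, concerns a different ring and bears on it only indirectly. A moderate drop is expected, a 4.0-fold lower number from compound 2 to compound 3 (0.60 log units; beyond the scatter). Compound 3 is estimated at 70 nM in this assay, within 15 nM to 350 nM.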

Compound 3, half-maximal inhibitory concentration: 60 nM
For compound 3 the middle estimate is 1.2-fold (0.07 log units) above the measured one; the measured number falls inside the stated range.
By their numbers in this assay, from the lowest: compounds 1 and 3 (each within the scatter of the next); then compound 2.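

In this assay, the position para to a large group proves able to take a ring with 2 hetero atoms: pyrimidin-2-yl in place of pyridin-4-yl gives a 4.7-fold lower number from compound 2 to compound 3 (0.67 log units; beyond the scatter). Against pyridin-2-yl the same change gives a 1.9-fold higher number from compound 1 to compound 3 (0.29 log units; within the scatter), so compound 1 and compound 3 cannot be told apart here. No measurement shown accounts for these results. As far as these compounds go, whether pyridin-3-yl would sit with compound 2 or with compound 1 stays open. So does whether an amine or a methoxy group on the pyrimidin-2-yl ring would be tolerated.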